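The compounds below may be only part of what the source reports. "The series", "measured", "known", "first", "only" and "open" are said of these compounds alone.

Measured in a functional assay on K562 cells (Homo sapiens) for antiproliferative activity, read by MTT assay, with a stated time of 72 h; a lower number here means a stronger inhibitor, a higher number a weaker inhibitor:

- Compound 1 `COc1cc(-n2ncnc2-c2ccc(Cl)c(Cl)c2)cc(OC)c1OC`: > 10000 nM (a limit)
- Compound 2 `COc1cc(-n2ncnc2-c2ccc(OC(C)C)cc2)cc(OC)c1OC`: 800 nM

Within the data shown here, compound 2 gives 800 nM, the only true number so far. Compound 1 gives > 10000 nM, which is a limit of the assay and not a number. Compound 2 therefore stands alone as a measured inhibitor of these cells, with no second number to compare it against. The two compounds share a core but differ in the groups on the outer ring, and no single-change comparison exists between them.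

The next compound is compound 3 `COc1cc(-n2ncnc2-c2ccc(F)cc2)cc(OC)c1OC`, which keeps the core of compound 2 and changes one group: fluoro in place of isopropoxy on an aromatic carbon. The isopropoxy group is replaced by fluoro, on the same aromatic carbon. Compound 1 also lacks the isopropoxy group, and its result is the limit > 10000 nM. That single comparison is weak support, but it leans towards a loss of activity in this assay. Expected here is a 5.0-fold higher number from compound 2 to compound 3 (0.70 log units; beyond the scatter), a weakening beyond the usual scatter, and the assay may report only a limit. The estimated value for compound 3 is 4000 nM, with an expected range from 1000 nM to 10000 nM.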

Compound 3, half-maximal inhibitory concentration: > 10000 nM
Compound 3 was reported as a limit (the forecaster's own chance of this, stated with the estimate: 40%); middle value at least 2.5-fold (0.39 log units) from the limit.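

In this assay, this result gives the first single-change test of the position para to a large group: fluoro in place of isopropoxy produces an at least 12-fold higher number from compound 2 to compound 3 (1.09 log units; beyond the scatter), a large loss of activity. With compound 1 there was no such test, as that compound differs from compound 2 in more than one place. The value of compound 3 is a limit of the assay and not a number, so this step gives only a minimum size, and compound 3 joins compound 1 at the same limit: the limit of > 10000 nM in this assay, at which 2 of the 3 values shown sit. Compound 1 and compound 3 both stand at limits, and the step between them cannot be read.

One step cannot tell whether the oxygen of the isopropoxy group or its carbons matter at this position, and methoxy, ethoxy or a plain isopropyl group would each separate these parts. Also open, on these data alone, is how other kinds of group on this carbon, such as an amine or a carboxylic acid, would fare in this assay.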